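The compounds below may be only part of what the source reports. "The series", "measured", "known", "first", "only" and "open" are said of these compounds alone.

Working notes on the series.

Compound 1 `COC(=O)/C=C/c1cccc(N(Cc2ccc(/C=C/c3scnc3C)cc2)C(=O)C2CCCCC2)c1` gives 227 nM in an assay on isolated protein with Bile acid receptor (Homo sapiens) as the target; a lower number here means that less compound is needed, a higher number that more compound is needed for the effect. Compound 2 `COC(=O)/C=C/c1cccc(N(Cc2ccc(/C=C/c3scnc3C)cc2)C(=O)C(C)C)c1` gives 228 nM in this assay, and the step of a 1.0-fold higher number from compound 1 to compound 2 (0.00 log units; within the scatter) shows that the exchange of isopropyl for cyclohexyl on the carbonyl carbon leaves the number unchanged. Compound 3 `COC(=O)/C=C/c1cccc(N(Cc2ccc(-c3cccc(OC)c3)cc2)C(=O)NC(C)C)c1` differs from compound 1 in two places at once; in this assay compound 3 gives 1370 nM. Among the three numbers, compound 1 holds the lowest; compound 2 sits within the scatter of it, while compound 3 lies beyond the scatter at a higher number.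

Compound 4 `COC/C=C/c1ccc(CN(C(=O)C2CCCCC2)c2cccc(/C=C/C(=O)OC)c2)cc1` is not yet measured. It differs from compound 1 as follows: methoxymethyl in place of 4-methyl-1,3-thiazol-5-yl on a double-bonded chain carbon bound to a double-bonded chain carbon. For the measured compounds named here, no measured step touches this position: the one step on record, from compound 1 to compound 2, concerns the carbonyl carbon, and compound 3 changes both the amide side and the ring-bearing arm together, so only its two values can be compared. The change at the double-bonded chain carbon is therefore unsupported by any directly comparable pair, and the expectation rests on the size of the group that leaves against the group that enters. A higher number is expected for compound 4, with the step of a 4.0-fold higher number from compound 1 to compound 4 (0.60 log units; beyond the scatter) estimated beyond the scatter. The estimate for compound 4 in this assay is 900 nM, within a range from 250 nM to 3500 nM.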

Compound 4, half-maximal effective concentration: 233 nM
Compound 4: middle estimate off by 3.9-fold (0.59 log units), on the high side; measured number below the stated range.
By their numbers in this assay, from the lowest: compounds 1, 2 and 4 (each within the scatter of the next); then compound 3.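

In this assay, for the compounds shown here, the step of a 1.0-fold higher number from compound 1 to compound 4 (0.01 log units; within the scatter) gives the first reading at this position, on a double-bonded chain carbon bound to a double-bonded chain carbon, and it lies within the scatter. For this pair, the five-membered aromatic ring of 4-methyl-1,3-thiazol-5-yl is therefore not needed to keep the number: methoxymethyl, with no ring and fewer heavy atoms, reads alike. Nothing available explains why these two groups read alike.

From the compounds shown here alone, whether this tolerance extends to other groups at this place, such as a carboxylic acid, an amine or a longer ether chain, stays open. Also open, going by these compounds, is whether methoxymethyl reads the same when isopropyl replaces cyclohexyl on the carbonyl carbon, as in compound 2.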